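Compound 2 to compound 3: swapping the nitrogen substituent

A few compounds are considered here, and "the series" means these few. Any claim that something is new, unique, unknown or untested is made for them only; others in the source may bear on it.

In an ADME assay on microsomes from liver (Mus musculus) for metabolic stability, with a stated time of 30 min, tested at 1 uM (on this read-out higher numbers stand for a more stable compound and lower numbers for a less stable compound), compound 1 `CCC1C(=O)N(C)c2cnc(-n3ccnc3-c3ccc(F)cc3)nc2N1c1ccc(F)cc1` gives 41%. Within the data shown here, compound 2 `CCC1C(=O)N(C)c2cnc(-n3ccnc3-c3ccc(F)cc3)nc2N1C1CCC(F)(F)C1` gives 15%, the lower of the two numbers measured so far. Among the measured compounds shown here, compound 3 `CCC1C(=O)N(C)c2cnc(-n3ccnc3-c3ccc(F)cc3)nc2N1c1ccc(C#N)cc1` has no measurement yet. It carries 4-cyanophenyl in place of 3,3-difluorocyclopentyl on a nitrogen on an aromatic ring in a ring.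

For the measured compounds named here, one measured step bears on this change: a number 26 percentage points lower from compound 1 to compound 2 (beyond the scatter), beyond the scatter, with 3,3-difluorocyclopentyl taking the place of 4-fluorophenyl at the same nitrogen. The change to compound 3 runs the other way, from the same 3,3-difluorocyclopentyl back to a six-membered aromatic ring of carbon only. Going by the values given here, no measurement yet compares 4-cyanophenyl with 4-fluorophenyl, and a single step is thin evidence. In this assay, an upward step of similar size is therefore expected, with wide uncertainty. The expected step is a number 25 percentage points higher from compound 2 to compound 3 (beyond the scatter). Compound 3 is estimated at 40%, with an expected range from 20% to 62%.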

Compound 3, percent of the compound remaining: 49%
Compound 3: the middle estimate sits 9 percentage points below what was measured; the range from low to high includes it.
By their numbers in this assay, from the lowest: compound 2; then compounds 1 and 3 (each within the scatter of the next).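

In this assay, the 3,3-difluorocyclopentyl group is now set against two aromatic groups on this nitrogen, and the result is the same in both cases: a number 26 percentage points lower from compound 1 to compound 2 (beyond the scatter), and a number 34 percentage points higher from compound 2 to compound 3 (beyond the scatter). The change on the phenyl ring itself is read differently, as cyano in place of fluoro gives a number 8 percentage points higher from compound 1 to compound 3 (within the scatter), so the 4-cyanophenyl and 4-fluorophenyl groups cannot be ordered on this read-out and the two substituents count as equivalent here. No measurement at hand accounts for the gap between the aromatic groups and the 3,3-difluorocyclopentyl group.

The compounds shown leave open how an unsubstituted phenyl or a plain cyclopentyl would stand on this nitrogen, so the part of the step that goes with the aromatic ring cannot be separated from the part that goes with the two fluorines on the cyclopentyl. Also open, from the compounds shown here alone, is whether a methoxy group or an amine in place of the cyano on the phenyl ring would stay level with compound 3 or fall towards compound 2.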